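Phenyl in place of sec-butyl on the core of compound 1

This account rests on a few compounds, and the source may have more. Where it says the series, first, only, none or still open, it means among the compounds named here.

Measured so far:
compound 1 `CCC(C)C1NC(=O)N(C2CCCC2)C1=O`: > 200000 nM, a limit of the assay
compound 2 `CCC(C)C(NC(=O)n1nnc2ccccc21)C(=O)NC1CCCCC1`: 98000 nM

Compound 1 has been tested in a functional assay on MOLT-4 cells (Homo sapiens) for inhibition; a lower number here means a stronger inhibitor, a higher number a weaker inhibitor. There compound 1 gives > 200000 nM, which is a limit of the assay and not a number (the limit of > 200000 nM in this assay, at which 1 of the 2 values shown sits). Compound 2, built on a different frame, gives 98000 nM in this assay. Among the compounds with values here, of this pair the two values show only that compound 2 returns a number where compound 1 returns a limit. Compound 3 `O=C1NC(c2ccccc2)C(=O)N1C1CCCC1` is the untested one. It differs from compound 1 by phenyl in place of sec-butyl on a saturated ring carbon. Within the data shown here, no measured pair shows this exchange, so the size of the step is open; it is expected to stay within the scatter, with little movement in either direction. Compound 3 is expected at 150000 nM, between 40000 nM and 600000 nM. The expected step is an at least 1.3-fold lower number from compound 1 to compound 3 (0.12 log units; that floor lies within the scatter).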

Compound 3, half-maximal inhibitory concentration: > 200000 nM
Compound 3: only a limit was reported; the forecaster's own chance of this, stated with the estimate: 60%; middle value at least 1.3-fold (0.12 log units) from the limit.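

In this assay compound 1 and compound 3 both return only a limit, so no step can be read between them: the limit of > 200000 nM in this assay, at which 2 of the 3 values shown sit.

The compounds shown leave open how phenyl and sec-butyl compare on the shared core, and whether either compound has any measurable inhibitory effect.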